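The source may hold more compounds than are shown below. What is called first, only, known or untested is meant among the compounds shown, and "the series" means these compounds.

Compound 1 `O=C(CCc1cccc(C(F)(F)F)c1)Nc1cc(Oc2ccc3nc(NC(=O)C4CC4)sc3c2)ccc1F` — > 50000 nM
Compound 2 `CCOC(=O)c1cccc(NC(=O)Nc2cc(Oc3ccc4nc(NC(=O)C5CC5)sc4c3)ccc2F)c1` — > 50000 nM

In an ADME assay on HT-29 cells (Homo sapiens) for cytotoxicity, read by luminescence and CellTiter-Glo, with a stated time of 12 h (a lower number here means that less compound is tolerated, a higher number that more compound is tolerated), compound 1 gives > 50000 nM, which is a limit of the assay rather than a number. Compound 2 gives > 50000 nM in this assay, again a limit and not a number. For the measured compounds named here, the one measured step is a step that the two limits leave unreadable from compound 1 to compound 2, so its size cannot be read. What the two measurements do show is the limit of > 50000 nM in this assay, at which 2 of the 2 values shown sit.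

Compound 3 `O=C(Nc1cccc(Br)c1)Nc1cc(Oc2ccc3nc(NC(=O)C4CC4)sc3c2)ccc1F` has not yet been measured in this assay. It differs from compound 2 by bromo in place of ethoxycarbonyl on an aromatic carbon. Going by the values given here, no measured step bears directly on this change, and the only step available is unreadable. Since both measured values sit at the limit of > 50000 nM in this assay, at which 2 of the 2 values shown sit, compound 3 is expected to stay there too, with the change from compound 2 to compound 3 estimated as a number no higher from compound 2 to compound 3 (the limit leaves the size open), not beyond the scatter. The estimate for compound 3 in this assay is 50000 nM, between 20000 nM and 100000 nM.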

Compound 3, half-maximal cytotoxic concentration: > 50000 nM
Compound 3: a limit, no number; the forecaster's own chance of this, stated with the estimate: 85%; the middle value sits exactly at the limit.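

In this assay compound 3 gives > 50000 nM and this is a limit, not a number. For the compounds shown here, no step among compound 1, compound 2 and compound 3 can be read, because all sit at one limit: the limit of > 50000 nM in this assay, at which 3 of the 3 values shown sit. The compounds shown leave open where each one's half-maximal cytotoxic concentration actually lies, and whether these changes alter it at all.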